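Aryl swap on the shared core: compound 3 outlook

The compounds below may be only part of what the source reports. "The series", "measured", "known", "first", "only" and "open" are said of these compounds alone.

Measured so far:
compound 1 `Cc1nc2c3ccccc3ccc2c2nc3c(ccc4ccccc43)c(-c3nccnc3N)c12` gives 81.7 ug/mL in a functional assay, read by spectrophotometry, with a stated time of 30 min; a higher number here means a weaker inhibitor, a lower number a stronger inhibitor
compound 2 `Cc1nc2c3ccccc3ccc2c2nc3c(ccc4ccccc43)c(-c3cc(O)nc4ccccc34)c12` gives 92.1 ug/mL in this assay

Compound 2 holds the highest of the two numbers, yet the gap between the two is only a 1.1-fold higher number from compound 1 to compound 2 (0.05 log units; within the scatter). Compound 3 `Cc1nc2c3ccccc3ccc2c2nc3c(ccc4ccccc43)c(-c3ccccc3)c12` carries phenyl in place of 2-hydroxyquinolin-4-yl on an aromatic carbon. Within the data shown here, the only step measured, a 1.1-fold higher number from compound 1 to compound 2 (0.05 log units; within the scatter), exchanged one bicyclic heteroaryl for another and stayed within the scatter; no measured step removes a donor and both acceptors from this position. On that basis compound 3 is expected to differ from compound 2 by a 1.0-fold higher number from compound 2 to compound 3 (0.01 log units; within the scatter), a step within the scatter. The estimate for compound 3 is 95 ug/mL, range 45 ug/mL to 200 ug/mL.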

Compound 3, half-maximal inhibitory concentration: 164 ug/mL
For compound 3 the middle estimate is 1.7-fold (0.24 log units) below the measured one; the range from low to high includes it.
By their numbers in this assay, from the lowest: compounds 1, 2 and 3 (each within the scatter of the next).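

In this assay phenyl, with 0 hydrogen-bond donors and 0 hydrogen-bond acceptors, stands on this aromatic carbon while both a 1.8-fold higher number from compound 2 to compound 3 (0.25 log units; within the scatter) and a 2.0-fold higher number from compound 1 to compound 3 (0.30 log units; within the scatter) stay within the scatter. Neither 2-hydroxyquinolin-4-yl nor 3-aminopyrazin-2-yl is therefore shown to be required here, even though these are the largest steps in the series so far. No supporting evidence bears on this result.

Still open, going by these compounds, is whether an amine or a carboxylic acid on the phenyl ring, or a saturated piperidine ring on this aromatic carbon, would give a step beyond the scatter.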